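The compounds below may be only part of what the source reports. "The series", "measured", "known", "first", "only" and "open" are said of these compounds alone.

Measured compounds and their numbers in an assay on HeLa cells for inhibition of Indoleamine 2,3-dioxygenase 1 (Homo sapiens); on this read-out higher numbers stand for weaker inhibition and lower numbers for stronger inhibition:
- compound 1, `O=C(Nc1ccc(Cl)cc1)C1(c2ccc3c(c2)CCN3c2ccccn2)CCC1`, gives 1.6 nM
- compound 2, `Cc1nccc(N2CCc3nc(C4(C(=O)Nc5ccc(F)cc5)CCC4)ccc32)n1`, gives 21 nM
- compound 3, `O=C(c1cccc(Cl)c1)N1CCc2nc(C3(C(=O)Nc4ccc(F)cc4)CCC3)ccc21`, gives 3 nM

Among these three, compound 3 sits between the others: its number is within the scatter of compound 1 and well apart from compound 2. The next compound, compound 4, `O=C(Nc1ccc(F)cc1)C1(c2ccc3c(n2)CCN3c2ccnc(C(F)(F)F)n2)CCC1`, is not yet measured. It differs from compound 3 in one place: 2-(trifluoromethyl)pyrimidin-4-yl in place of (3-chlorophenyl)carbonyl on a nitrogen on an aromatic ring in a ring.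

Among the compounds with values here, one measured step bears directly on this change. Going a 7.0-fold lower number from compound 2 to compound 3 (0.85 log units; beyond the scatter), the same kind of swap ran in the opposite direction, with a pyrimidinyl group replaced by the chlorophenylcarbonyl group. Within the data shown here, compound 4 reverses that swap, though its pyrimidinyl carries a trifluoromethyl where compound 2 carries a methyl; no measured pair shows what that smaller difference does. The expectation is therefore a higher number, beyond the scatter, of a size similar to a 5.0-fold higher number from compound 3 to compound 4 (0.70 log units; beyond the scatter). Compound 4 is estimated at 15 nM in this assay, within a range of 4 nM to 60 nM.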

Compound 4, half-maximal inhibitory concentration: 127 nM
The estimate for compound 4 lay 8.5-fold (0.93 log units) below the measured number; the measured number lies above the stated range.
By their numbers in this assay, from the lowest: compounds 1 and 3 (each within the scatter of the next); then compound 2; then compound 4.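

In this assay, placing 2-(trifluoromethyl)pyrimidin-4-yl instead of (3-chlorophenyl)carbonyl on this nitrogen gives a 42-fold higher number from compound 3 to compound 4 (1.63 log units; beyond the scatter) as its outcome, a much bigger step than a 7.0-fold lower number from compound 2 to compound 3 (0.85 log units; beyond the scatter) seen before. The group on the pyrimidine ring also counts: trifluoromethyl in place of methyl on an aromatic carbon gives a 6.0-fold higher number from compound 2 to compound 4 (0.78 log units; beyond the scatter) on its own, so the number here depends on more than the choice between a pyrimidinyl and a carbonyl group. No measured evidence accounts for either step.

Still open, on these data alone, is how a pyrimidin-4-yl group with no substituent, or one carrying a methoxy group or an amine instead, would behave on this nitrogen. Also open, as far as these compounds go, is how much of the result for compound 3 belongs to the carbonyl and how much to the chlorophenyl ring, which a plain acetyl group on the same nitrogen could help separate.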